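This account rests on a few compounds, and the source may have more. Where it says the series, first, only, none or still open, it means among the compounds named here.

Working notes on the series. All three measured compounds carry the same core and differ only in the group on the amide-type nitrogen. Compound 1 `COc1ccc(C(C)NC(=O)/N=C(\N)NCCCc2sc(N)nc2C)cc1` gives 0.91 in a functional assay on Right cardiac atrium for agonist activity at histamine H2 receptor (Cavia porcellus), with a stated time of 30 min, in the presence of a further agent that is not named here; a higher number here means a larger maximal response, a lower number a smaller maximal response. Compound 2 `Cc1nc(N)sc1CCCN/C(N)=N/C(=O)N[C@H](C)c1ccccc1` gives 0.95, and compound 3 `Cc1nc(N)sc1CCCN/C(N)=N/C(=O)NC(C)c1ccc(Br)cc1` gives 0.87. Compound 2 holds the highest of the three numbers, but its nearest neighbour is compound 1 and its furthest is compound 3, and both gaps are within the scatter, so no order among the three can be claimed. Within the data shown here, the one single-point step measured so far runs from compound 1 to compound 3, a number 0.040 lower from compound 1 to compound 3 (within the scatter), and is within the scatter.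

Compound 4 `Cc1nc(N)sc1CCCN/C(N)=N/C(=O)NCc1ccco1` has not yet been measured. It differs from compound 2 by (furan-2-yl)methyl in place of 1-phenylethyl on an amide-type nitrogen. Among the measured compounds shown here, this change is of a different kind from the measured step, which only swapped one substituent on the aromatic ring while the 1-phenylethyl group stayed; no measured pair tells directly how the whole group matters. Since every variation seen so far leaves the maximal response essentially unchanged, the step a number 0.070 lower from compound 2 to compound 4 (within the scatter) is expected to stay within the scatter, with a wider margin to allow for the untested kind of change. For compound 4 the expected value is 0.88, with a range from 0.72 to 1.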

Compound 4, intrinsic activity: the largest response reached, as a fraction of the reference agonist's: 0.58
Compound 4: the middle estimate sits 0.30 above what was measured; measured number below the stated range.
By their numbers in this assay, from the lowest: compound 4; then compounds 3, 1 and 2 (each within the scatter of the next).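

In this assay, among these compounds, the step a number 0.37 lower from compound 2 to compound 4 (beyond the scatter) is the first to lie beyond the scatter, so the group on the amide-type nitrogen is a place where the maximal response can change, which the bromo-for-methoxy swap on the aromatic ring did not reveal. The change from 1-phenylethyl to (furan-2-yl)methyl alters several things at once: a six-membered aromatic ring of carbon only gives way to a five-membered aromatic ring with an oxygen, a hydrogen-bond acceptor enters, the group becomes smaller, and the defined stereocentre is lost, so this one step cannot assign the loss of response to any single one of these features. Nothing available bears on the reason for this step.

The compounds shown leave open whether the ring or the branched carbon carrying the methyl matters more for the maximal response. A benzyl group on the same nitrogen would keep the phenyl ring without the branch, and a 1-(furan-2-yl)ethyl group would keep the branch with the furan ring, so the two would separate these features.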